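Removing the methoxy from the chromone series: compound 4

The source may report more compounds than this note shows. Statements on the series, on what has been measured and on what is new or still open speak of the compounds shown alone.

Compound 1 `COc1ccc2occ(CSC(=S)N(C(C)C)C(C)C)c(=O)c2c1` gives 4800 nM in a functional assay on SW480 cells (Homo sapiens) for antiproliferative activity, read by MTT assay, with a stated time of 72 h (on this read-out lower numbers stand for stronger inhibition and higher numbers for weaker inhibition), the lowest of the two numbers obtained. Compound 3 `COc1ccc2occ(CSC(=S)N3CCOCC3)c(=O)c2c1` gives 7100 nM in this assay, and the step of a 1.5-fold higher number from compound 1 to compound 3 (0.17 log units; within the scatter) stays within the scatter. Compound 2 `CC(C)N(C(=S)SCc1cc(=O)c2ccc(Cl)cc2o1)C(C)C` reaches only a limit of this assay, > 25000 nM, as noted in the limit of > 25000 nM in this assay, at which 1 of the 3 values shown sits. Compound 4 `CC(C)N(C(=S)SCc1coc2ccccc2c1=O)C(C)C` differs from compound 1 by hydrogen in place of methoxy on an aromatic carbon. Within the data shown here, no measured step bears on this change: the only step measured, from diisopropylamino to morpholinyl, touches a different part of the molecule and was within the scatter. The step of a 1.7-fold higher number from compound 1 to compound 4 (0.22 log units; within the scatter) is therefore only an expectation, with wide uncertainty. For compound 4 the estimate in this assay is 8000 nM, ranging from 3000 nM to 25000 nM.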

Compound 4, half-maximal inhibitory concentration: 6800 nM
Beside the measured number, compound 4's estimate is 1.2-fold (0.07 log units) above it; low and high end bracket the measured number.
By their numbers in this assay, from the lowest: compounds 1, 4 and 3 (each within the scatter of the next). At a limit, above all of these: compound 2.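

In this assay, hydrogen in place of methoxy on this aromatic carbon gives a 1.4-fold higher number from compound 1 to compound 4 (0.15 log units; within the scatter), so the methoxy can be lost here without a change beyond the scatter. The other single change shown, a 1.5-fold higher number from compound 1 to compound 3 (0.17 log units; within the scatter), is also within the scatter, so neither site has yet moved the number measurably. Nothing shown gives a reason for this result.

Going by these compounds, whether an amine, a carboxylic acid or a longer alkoxy chain on this same aromatic carbon would shift the number beyond the scatter remains open.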